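The source may report more compounds than this note shows. Statements on the series, on what has been measured and on what is new or still open speak of the compounds shown alone.

Compound 1, `CC(=O)Nc1ccc(OC(=S)Nc2ccc(Oc3ccc(C(Cl)(Cl)Cl)cc3)cc2)cc1`, gives 6.16 in a physicochemical assay for lipophilicity; a lower number here means a more polar compound, a higher number a more lipophilic compound.
Compound 2, `Oc1ccc(OC(=S)Nc2ccc(Nc3ccc(C(Cl)(Cl)Cl)cc3)cc2)cc1`, gives 6.79 in this assay.
Compound 3, `CC(=O)Nc1ccc(OC(=S)Nc2ccc(Oc3ccc([N+](=O)[O-])cc3)cc2)cc1`, gives 4.81 in this assay.

Compound 1 and compound 3 differ in one place: nitro in place of trichloromethyl on an aromatic carbon. This change made a step of a number 1.35 log units lower from compound 1 to compound 3 (beyond the scatter). Compound 2 has the highest number of the three measured compounds; the difference between its core and the core of compound 1 is not broken down here. Compound 4, `O=[N+]([O-])c1ccc(Nc2ccc(NC(=S)Oc3ccc(O)cc3)cc2)cc1`, has not yet been measured in this assay. It differs from compound 2 by the same change, at the same place: nitro in place of trichloromethyl on an aromatic carbon. Within the data shown here, a step of similar size is expected here, because the only measured step of this kind was a number 1.35 log units lower from compound 1 to compound 3 (beyond the scatter). The step from compound 2 to compound 4 is therefore expected to be a number 1.35 log units lower from compound 2 to compound 4 (beyond the scatter). For compound 4 a value near 5.44 is estimated, most likely between 5 and 5.9.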

Compound 4, partition coefficient: 4.54
The estimate for compound 4 lay 0.90 log units above the measured number, outside the stated range (below it).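

The change from trichloromethyl to nitro gave a number 2.25 log units lower from compound 2 to compound 4 (beyond the scatter), against a number 1.35 log units lower from compound 1 to compound 3 (beyond the scatter) on the other core. In this assay, the direction carried over between these two cores and both steps are large, but the printed sizes are not the same, so the step from one core did not transfer as a fixed amount. Two pairs establish no rule for the series, and nothing shown here explains the different sizes.

The compounds shown leave open how an amine or a carboxylic acid on that aromatic carbon would compare with nitro and trichloromethyl. They also leave open what size of step the same change would give on a third core.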